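Chloro to hydrogen on two cores: cytotoxicity notes

The source may report more compounds than this note shows. Statements on the series, on what has been measured and on what is new or still open speak of the compounds shown alone.

Of the compounds shown here, three have so far been measured in a functional assay on SW480 cells (Homo sapiens) for cytotoxicity, read by MTT assay, with a stated time of 72 h; on this read-out higher numbers stand for weaker inhibition and lower numbers for stronger inhibition. Compound 1 `O=c1cc(CSc2nc3ccccc3s2)oc2ccccc12` reaches only a limit of the assay: in this assay compound 1 gives > 25000 nM. Compound 2 `O=c1cc(CSc2nc3ccccc3s2)oc2ccc(Cl)cc12` likewise reaches only a limit of the assay: in this assay compound 2 gives > 25000 nM. Compound 3 `Cc1cc(C)n2nc(SCc3cc(=O)c4cc(Cl)ccc4o3)nc2n1` also reaches only a limit of the assay: in this assay compound 3 gives > 25000 nM. All shown values therefore sit at the limit of > 25000 nM in this assay, at which 3 of the 3 values shown sit.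

Compounds 2 and 1 differ by hydrogen in place of chloro on an aromatic carbon. The step that the two limits leave unreadable from compound 2 to compound 1 cannot be read, since both ends are limits. Compound 3 carries a different core from compound 2; the difference between the two cores is not broken down here.

Compound 4 `Cc1cc(C)n2nc(SCc3cc(=O)c4ccccc4o3)nc2n1` is not yet measured. It differs from compound 3 by hydrogen in place of chloro on an aromatic carbon, which is the same change as that made from compound 2 to compound 1, at a place described in the same words.

The step this change is expected to make is a step that the limit leaves unreadable from compound 3 to compound 4, an expectation that rests on the earlier step being unreadable and on (the limit of > 25000 nM in this assay, at which 3 of the 3 values shown sit), at which every shown value sits. For compound 4 the expected value in this assay is 30000 nM, with a range from 15000 nM to 80000 nM, and a limit rather than a number is the likelier outcome.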

Compound 4, half-maximal inhibitory concentration: > 25000 nM
Compound 4 ended at the assay's limit (the forecaster's own chance of this, stated with the estimate: 85%); the middle value is on the limit's open side.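

No new step can be read: compound 3 and compound 4 both stand at a limit in this assay, so the change from chloro to hydrogen has no readable size on this core, and the same holds for compound 2 and compound 1: the limit of > 25000 nM in this assay, at which 4 of the 4 values shown sit.

The compounds shown leave open whether chloro or hydrogen at this place makes any difference to cytotoxicity on either core, and at what concentration any of the four compounds would show an effect.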